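This account rests on a few compounds, and the source may have more. Where it says the series, first, only, none or still open, it means among the compounds named here.

Measured in a functional assay on KB cells (Homo sapiens) for antiproliferative activity, read by sulforhodamine B assay, with a stated time of 48 h; a higher number here means a weaker inhibitor of growth, a lower number a stronger inhibitor of growth:
- Compound 1 `COc1ccc(S(=O)(=O)Nc2ccc(CCc3ccc(C(=O)Nc4ccccc4N)cc3)cc2)cc1`: > 10000 nM (a limit)
- Compound 2 `COc1ccc(S(=O)(=O)Nc2ccccc2CCc2ccc(C(=O)NO)cc2)cc1`: > 10000 nM (a limit)
- Compound 3 `COc1ccc(S(=O)(=O)Nc2ccccc2-c2ccc(C(=O)Nc3ccccc3N)cc2)cc1`: 442 nM

Compound 2 sits at the limit of > 10000 nM in this assay, at which 2 of the 3 values shown sit, so its true position is not known as a number. Compound 4 `COc1ccc(S(=O)(=O)Nc2ccccc2CCc2ccccc2)cc1` has hydrogen in place of hydroxycarbamoyl on an aromatic carbon, para to a large group: hydrogen in place of hydroxycarbamoyl on an aromatic carbon. Within the data shown here, no measured pair shows this change, so the expectation rests on compound 2 alone. No gain in growth inhibition is expected, and the expected step that the limit leaves unreadable from compound 2 to compound 4 is no larger than the scatter. In this assay the reading will most likely be only a limit again. Compound 4 is estimated at 12000 nM, with an expected range of 4000 nM to 30000 nM.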

Compound 4, concentration for 50% growth inhibition: 4410 nM
Beside the measured number, compound 4's estimate is 2.7-fold (0.43 log units) above it; measured number inside the range.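

In this assay, the change from 4-(hydroxycarbamoyl)phenyl to phenyl gives an at least 2.2-fold lower number from compound 2 to compound 4 (0.35 log units; beyond the scatter). Among these compounds, this is the first reading of this position, and it shows that the hydroxycarbamoyl group is not needed for a measurable number on this core, since compound 4 carries only hydrogen there. The step can be stated only as a minimum because compound 2 has no exact value: the limit of > 10000 nM in this assay, at which 2 of the 4 values shown sit.

Going by these compounds, the true size of the step remains open. So does whether a carboxylic acid or an amine in this place would give a lower or a higher number than hydrogen.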